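Thiosemicarbazone aryl variation in a lung cancer cell growth assay

The source may report more compounds than this note shows. Statements on the series, on what has been measured and on what is new or still open speak of the compounds shown alone.

Compound 1 `COc1ccc(/C=N\NC(=S)NC(C)(C)CCC[C@](C)(O)[C@@H]2CC=C(C)CC2)cc1` carries a methoxy-substituted arylidene thiosemicarbazide on a terpenoid core. Among the compounds with values here, in a functional assay on NCI-H460 cells (Homo sapiens) for cytotoxicity, read by sulforhodamine B assay (a higher number here means a weaker inhibitor of growth, a lower number a stronger inhibitor of growth), compound 1 gives 5100 nM, the lowest of the two numbers so far. Its neighbour compound 2 `CC1=CC[C@@H]([C@@](C)(O)CCCC(C)(C)NC(=S)N/N=C\c2ccc([N+](=O)[O-])cc2)CC1`, in which nitro replaces methoxy on an aromatic carbon, gives 10100 nM in this assay, and the step of a 2.0-fold higher number from compound 1 to compound 2 (0.30 log units; within the scatter) lies within the scatter. Compound 3 `CC1=CC[C@@H]([C@@](C)(O)CCCC(C)(C)NC(=S)N/N=C(/C)c2ccccc2)CC1` differs from compound 1 by a group of 9 heavy atoms (8 carbon, 1 nitrogen; one six-membered aromatic ring of carbon only) in place of a group of 10 heavy atoms (8 carbon, 1 nitrogen, 1 oxygen; one six-membered aromatic ring of carbon only), on an amide-type nitrogen. Within the data shown here, no measured step concerns this change; the only step known, from a methoxy to a nitro group, shows that a substituent swap on that ring moved the number little. The same modest outcome is expected here, without a direction beyond the scatter. Compound 3 is therefore estimated at 6500 nM, with a range from 2500 nM to 17000 nM. That estimate corresponds to an expected step of a 1.3-fold higher number from compound 1 to compound 3 (0.11 log units; within the scatter).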

Compound 3, concentration for 50% growth inhibition: 12600 nM
Estimate against measurement, compound 3: 1.9-fold (0.29 log units) below; measured number inside the range.
By their numbers in this assay, from the lowest: compounds 1, 2 and 3 (each within the scatter of the next, the first and the last beyond it).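

In this assay, within the data shown here, the replacement of the whole group on the amide-type nitrogen gives a 2.5-fold higher number from compound 1 to compound 3 (0.39 log units; beyond the scatter), the first step to pass beyond the scatter, though it remains modest. The earlier swap of methoxy for nitro on the aromatic ring did not show that this position could move the number measurably. Compound 3, which has no oxygen in the group entering at this position, stands within the scatter of compound 2, so the series does not separate these two. The data offer no explanation for the step. The compounds shown leave open which part of the exchanged group carries the step, and how an amine or a carboxylic acid on the aromatic ring would read in this assay.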